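Adding an Ethyl Group to the Phenyl of Compound 2

A few compounds are considered here, and "the series" means these few. Any claim that something is new, unique, unknown or untested is made for them only; others in the source may bear on it.

Of the compounds shown here, two have been measured so far. Compound 1 `O=C(NO)c1ccc(NCc2nc(-c3cc4ccccc4s3)nn2-c2ccccc2)cc1` was tested in an assay on Sf9 cells for inhibition of protein deacetylase HDAC6 (Homo sapiens), read by fluorescence, with a stated time of 40 min, tested at 100 nM (on this read-out higher numbers stand for more inhibition at the one concentration tested (going by the name of the read-out) and lower numbers for less inhibition), and compound 1 gives 65.5%. Compound 2 `O=C(NO)c1ccc(NCc2nc(-c3ccccc3)nn2-c2ccccc2)cc1`, which carries a phenyl in place of the 1-benzothiophen-2-yl group on an aromatic carbon, gives 72.6% in this assay. The step of a number 7.1 percentage points higher from compound 1 to compound 2 (within the scatter) is within the scatter, so compound 2 and compound 1 stand at the same level as far as these two numbers can tell.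

Compound 3 `CCc1ccc(-n2nc(-c3ccccc3)nc2CNc2ccc(C(=O)NO)cc2)cc1` differs from compound 2 by ethyl in place of hydrogen on an aromatic carbon. Within the data shown here, no measured step touches this part of the molecule: the only step known, a number 7.1 percentage points higher from compound 1 to compound 2 (within the scatter), changes a different group, sits elsewhere on the shared core and is itself within the scatter. There is therefore no basis for expecting a step beyond the scatter in either direction in this assay. This estimate means an expected step of a number 2.6 percentage points lower from compound 2 to compound 3 (within the scatter), staying within the scatter. Compound 3 is accordingly expected to give about 70% in this assay, with a range from 55% to 85%.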

Compound 3, a percentage reported as inhibition, at one concentration (the size of the read-out at that concentration, not a potency): 38.3%
Beside the measured number, compound 3's estimate is 31.7 percentage points above it; the whole stated range lies above it.
By their numbers in this assay, from the lowest: compound 3; then compounds 1 and 2 (each within the scatter of the next).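

Putting ethyl in place of hydrogen, turning phenyl into 4-ethylphenyl, gives a number 34.3 percentage points lower from compound 2 to compound 3 (beyond the scatter) in this assay. This shows that the aromatic carbon para to a large group is not a place where any change passes unnoticed: even a group as simple as ethyl can shift the number well beyond ordinary assay variation. The earlier step, a number 7.1 percentage points higher from compound 1 to compound 2 (within the scatter), could not show this, as it changed a different part of the molecule and stayed within the scatter, and no measurement here explains the drop from the ethyl group.

As far as these compounds go, with only one substituent at this position, it remains open whether the drop is particular to ethyl or would also appear with a methyl, a fluorine, a methoxy or a longer chain such as propyl. From the compounds shown here alone, it is also open whether ethyl at another carbon of the same ring would lower the number as far, and how a full concentration series would compare compound 2 and compound 3, since this read-out gives inhibition at one concentration and not a potency.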